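Changing the acyl group on an inactive amide

The compounds below may be only part of what the source reports. "The series", "measured", "known", "first", "only" and "open" are said of these compounds alone.

Compound 2 `O=C(Nc1cc(Sc2ncn[nH]2)c(O)c2ccccc12)c1cccc(Cl)c1` is one of three compounds sharing the same core. In a functional assay on MDA-MB-231 cells (Homo sapiens) for antiproliferative activity, read by MTT assay, with a stated time of 48 h (a lower number here means a stronger inhibitor, a higher number a weaker inhibitor), compound 2 gives only a limit of the assay, > 100000 nM. Compound 1 `Cc1nnc(Sc2cc(NC(=O)c3ccc(Cl)cc3)c3ccccc3c2O)s1` likewise reaches only the limit, > 100000 nM. Compound 3 `O=C(Nc1cc(Sc2ncnc3nc[nH]c23)c(O)c2ccccc12)c1ccc([N+](=O)[O-])cc1` also stops at the limit, > 100000 nM. Nothing shown here separates any two of these compounds, so no direction can be read from them for a new change. Compound 4 `O=C(/C=C/c1ccc(Cl)cc1)Nc1cc(Sc2ncn[nH]2)c(O)c2ccccc12` differs from compound 2 in one place: 2-(4-chlorophenyl)ethenyl in place of 3-chlorophenyl on a carbonyl carbon. Given (the limit of > 100000 nM in this assay, at which 3 of the 3 values shown sit), compound 4 is expected to remain near that limit, with the step that the limit leaves unreadable from compound 2 to compound 4 expected to lie within the scatter. The estimate for compound 4 is 150000 nM, with a range from 30000 nM to 600000 nM.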

Compound 4, half-maximal inhibitory concentration: > 100000 nM
Compound 4: only a limit was reported; the forecaster's own chance of this, stated with the estimate: 80%; the middle value is on the limit's open side.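

The step from compound 2 to compound 4 cannot be read, since each compound gives only a limit of the assay. The compounds shown leave open which change, if any, would give a measured number rather than a limit in this assay.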